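A few compounds are considered here, and "the series" means these few. Any claim that something is new, unique, unknown or untested is made for them only; others in the source may bear on it.

In a functional assay on MCF7 cells (Homo sapiens) for antiproliferative activity, read by CellTiter-Glo, with a stated time of 5 days (a higher number here means a weaker inhibitor, a lower number a stronger inhibitor), compound 1 `O=C(O)/C=C/c1ccc(/C(=C(\c2ccccc2)C2CCC2)c2ccc3scnc3c2)cc1` gives 16 nM while compound 2 `N#Cc1ccc(/C(=C(\c2ccc(/C=C/C(=O)O)cc2)c2ccc3scnc3c2)C2CCC2)c(Cl)c1` gives 1.4 nM and compound 3 `N#Cc1cc(Cl)ccc1/C(=C(\c1ccc(/C=C/C(=O)O)cc1)c1ccc2scnc2c1)C1CCC1` gives 0.9 nM at the low end of the series, level within the scatter with compound 2 (a 1.6-fold lower number from compound 2 to compound 3 (0.19 log units; within the scatter)). Compound 4 `O=C(O)/C=C/c1ccc(/C(=C(\c2ncc(C(F)(F)F)cc2Cl)C2CCC2)c2ccc3scnc3c2)cc1` carries 3-chloro-5-(trifluoromethyl)pyridin-2-yl in place of 4-chloro-2-cyanophenyl (3-chloro-5-(trifluoromethyl)pyridin-2-yl in place of 4-chloro-2-cyanophenyl on a double-bonded chain carbon bound to a double-bonded chain carbon and a saturated ring carbon). At this carbon the steps away from phenyl were large (an 11-fold lower number from compound 1 to compound 2 (1.06 log units; beyond the scatter); an 18-fold lower number from compound 1 to compound 3 (1.25 log units; beyond the scatter)), and the exchange between the two chloro-and-nitrile rings moved nothing beyond the scatter. For the measured compounds named here, no measured compound holds the entering group, so the read-across is loose. The expected step is small and toward a higher number (a 1.7-fold higher number from compound 3 to compound 4 (0.22 log units; within the scatter)), not clearly beyond the scatter. Compound 4 is estimated at 1.5 nM (expected range 0.5 nM to 6 nM).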

Compound 4, half-maximal inhibitory concentration: 2.9 nM
Compound 4: middle estimate off by 1.9-fold (0.29 log units), on the low side; the measured number falls inside the stated range.
By their numbers in this assay, from the lowest: compounds 3 and 2 (each within the scatter of the next); then compound 4; then compound 1.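

At this carbon, a ring without a nitrile still holds a clear gain over phenyl (a 5.5-fold lower number from compound 1 to compound 4 (0.74 log units; beyond the scatter)), so the gain is not confined to the two chloro-and-nitrile rings. That gain is smaller than theirs (a 3.2-fold higher number from compound 3 to compound 4 (0.51 log units; beyond the scatter)) (a 2.1-fold higher number from compound 2 to compound 4 (0.32 log units; beyond the scatter)), and in this assay this exchange, unlike the one between the two chloro-and-nitrile rings, lies beyond the scatter.

No evidence on hand bears on why this ring differs from the other two. The exchange alters the ring nitrogen and the trifluoromethyl together, leaving their separate contributions open, as well as how a ring carrying an amine at this carbon would compare.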